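Replacing the methylsulfonyl group of compound 1

The compounds below may be only part of what the source reports. "The series", "measured", "known", "first", "only" and "open" are said of these compounds alone.

For the measured compounds named here, in an ADME assay on HepG2 cells (Homo sapiens) for cytotoxicity, read by CellTiter-Glo, with a stated time of 48 h (on this read-out lower numbers stand for higher toxicity in this test and higher numbers for lower toxicity in this test), compound 1 `COc1ccc2nc(NC3CCCCC3)c(S(C)(=O)=O)nc2c1` gives 12600 nM and compound 2 `COc1ccc2nc(NCC(C)C)c(S(C)(=O)=O)nc2c1` gives 12600 nM, so compound 1 stands level with its only measured neighbour. Compound 3 `COc1ccc2nc(NC3CCCCC3)c([S+](C)[O-])nc2c1` keeps the core of compound 1 and changes one group: a group of 3 heavy atoms (1 carbon, 1 oxygen, 1 sulfur; no ring) in place of a group of 4 heavy atoms (1 carbon, 2 oxygen, 1 sulfur; no ring), on an aromatic carbon. Going by the values given here, the only measured step, no change at the digits printed from compound 1 to compound 2 (within the scatter), changes a different group, so it bears on this change only indirectly. Among the compounds with values here, no measured step touches the methylsulfonyl group. With so little to go on, no shift beyond the scatter is expected in this assay. Compound 3 is estimated at 12600 nM, within 5500 nM to 30000 nM. The expected step is no change at the digits printed from compound 1 to compound 3 (within the scatter).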

Compound 3, half-maximal cytotoxic concentration: 12600 nM
The estimate for compound 3 equals the measured number at the digits printed; measured number inside the range.
By their numbers in this assay, from the lowest: compounds 1, 2 and 3 (each within the scatter of the next).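

In this assay, the methylsulfonyl group on this aromatic carbon gives way to the group of 3 heavy atoms, which carries one oxygen fewer, with no change at the digits printed from compound 1 to compound 3 (within the scatter). For the compounds shown here, this is the first measured change at this position, and the two sulfur groups cannot be told apart in this read-out. Nothing available accounts for this result.

Open, going by these compounds, is whether a sulfur group is needed here at all: an amine, a carboxylic acid or a plain hydrogen on this carbon could read differently. Also open, on these data alone, is whether the same swap reads alike with isobutyl on the nitrogen.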